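A few compounds are considered here, and "the series" means these few. Any claim that something is new, unique, unknown or untested is made for them only; others in the source may bear on it.

For the measured compounds named here, compound 3 `Cc1nc(C(NC(=O)C(=O)Nc2ccc(Cl)c(F)c2)C2CCCCN2)sc1CO` is the only one of the three compounds whose result in an ADME assay on TZM-b1 cells (Homo sapiens) for cytotoxicity, read by XTT assay, with a stated time of 3 days (on this read-out higher numbers stand for lower toxicity in this test and lower numbers for higher toxicity in this test), is a number, at 58400 nM. Compound 2 `Cc1nc(C(NC(=O)C(=O)Nc2ccc(C(F)(F)F)cc2)C2CCCCN2)sc1CO` reaches only the limit of this assay at > 75500 nM. Compound 1 `Cc1nc(C(NC(=O)C(=O)Nc2ccc(F)cc2)C2CCCCN2)sc1CCO` likewise reaches only a limit of this assay, at > 88000 nM. Going by the values given here, the single measured step, an at least 1.2-fold lower number from compound 2 to compound 3 (0.11 log units; that floor lies within the scatter), is thus a floor rather than a true difference. Compound 4 `Cc1nc(C(NC(=O)C(=O)Nc2ccc(F)cc2)C2CCCCN2)sc1CO` differs from compound 3 by 4-fluorophenyl in place of 4-chloro-3-fluorophenyl on an amide-type nitrogen. Among the compounds with values here, no measured step bears directly on this change, and because the limit of > 75500 nM in this assay, at which 1 of the 3 values shown sits, and the limit of > 88000 nM in this assay, at which 1 of the 3 values shown sits, leave all three values close together, no movement beyond the scatter is expected. The step from compound 3 is expected as a 1.4-fold higher number from compound 3 to compound 4 (0.14 log units; within the scatter). Compound 4 is therefore expected to give about 80000 nM, within 45000 nM to 150000 nM.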

Compound 4, half-maximal cytotoxic concentration: > 90000 nM
Compound 4 was reported as a limit (the forecaster's own chance of this, stated with the estimate: 60%); at least 1.1-fold (0.05 log units) between middle value and limit.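

In this assay, the change to 4-fluorophenyl from 4-chloro-3-fluorophenyl on an amide-type nitrogen now has a measured step, an at least 1.5-fold higher number from compound 3 to compound 4 (0.18 log units; that floor lies within the scatter). This gives only a floor, so the change cannot be said to move the read-out beyond the usual scatter. Compound 4 gives a limit and not a number: the limit of > 90000 nM in this assay, at which 1 of the 4 values shown sits. The steps to compound 4 from compound 2 and from compound 1 cannot be read, as both ends of each are limits.

The compounds shown leave open the true size of the step from compound 3 to compound 4. They also leave open how an amine or a carboxylic acid on the phenyl ring would read in this assay.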